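From Pyridin-3-yl to (3-Methylphenyl)amino on the Carbonyl Carbon

The compounds below may be only part of what the source reports. "The series", "measured", "known", "first", "only" and "open" are said of these compounds alone.

Compound 1 `Nc1nc(N2CCN(C(=O)COc3ccc(Cl)cc3)CC2)c2cc(F)sc2n1`: 700 nM
Compound 2 `Nc1nc(N2CCN(C(=O)C3CCCCC3)CC2)c2cc(F)sc2n1`: > 10000 nM
Compound 3 `Nc1nc(N2CCN(C(=O)c3cccnc3)CC2)c2cc(F)sc2n1`: > 10000 nM

Three compounds share one core and differ only in the group on a carbonyl carbon. In a functional assay on cells (Lymphocyte) (a lower number here means a stronger inhibitor, a higher number a weaker inhibitor), compound 1 gives 700 nM. For compound 2 the result is only a limit, > 10000 nM. For compound 3 the result is likewise only a limit, > 10000 nM. So compound 3 stands at the weak end of what has been seen, sharing that place with compound 2 (the limit of > 10000 nM in this assay, at which 2 of the 3 values shown sit).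

Compound 4 `Cc1cccc(NC(=O)N2CCN(c3nc(N)nc4sc(F)cc34)CC2)c1` is the next compound. (3-methylphenyl)amino in place of pyridin-3-yl on a carbonyl carbon The steps seen so far say that leaving the (4-chlorophenoxy)methyl group costs a lot: an at least 14-fold higher number from compound 1 to compound 3 (1.15 log units; beyond the scatter) and an at least 14-fold higher number from compound 1 to compound 2 (1.15 log units; beyond the scatter). Between the two weak compounds the step is unreadable: a step that the two limits leave unreadable from compound 2 to compound 3. Going by the values given here, no measured step carries the (3-methylphenyl)amino group, so the expectation leans on compound 1, whose carbonyl also bears a single aromatic ring held off by one linking atom and gives 700 nM. A moderate gain is expected, an at least 3.3-fold lower number from compound 3 to compound 4 (0.52 log units; beyond the scatter), so compound 4 is estimated at 3000 nM, within 500 nM to 15000 nM.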

Compound 4, half-maximal inhibitory concentration: 2800 nM
Beside the measured number, compound 4's estimate is 1.1-fold (0.03 log units) above it; the measured number falls inside the stated range.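

The (3-methylphenyl)amino group gives a readable number on this carbonyl carbon in this assay, which neither pyridin-3-yl nor cyclohexyl did: an at least 3.5-fold lower number from compound 3 to compound 4 (0.55 log units; beyond the scatter) and an at least 3.5-fold lower number from compound 2 to compound 4 (0.55 log units; beyond the scatter). Going by these compounds alone, the (4-chlorophenoxy)methyl group is therefore not the only group here that gives a readable value, although it keeps the lead, with a 4.0-fold higher number from compound 1 to compound 4 (0.60 log units; beyond the scatter). The first two steps give only a minimum size, because compound 2 and compound 3 each stand at a limit: the limit of > 10000 nM in this assay, at which 2 of the 4 values shown sit.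

The compounds shown leave open which part of the (3-methylphenyl)amino group matters, the amide hydrogen or the methyl group on the ring. A plain phenylamino group would test the methyl group, and a (3-methylphenyl)methyl group, which has no amide hydrogen, would test the other.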